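The source may hold more compounds than are shown below. What is called first, only, known or untested is meant among the compounds shown, and "the series" means these compounds.

Measured so far:
compound 1, `COc1ccc(N2C(=O)C(C)(C)c3cccnc32)cc1`, 0%
compound 2, `CC(C)(C(=O)O)c1cccnc1Nc1ccc(Cl)cc1`, 34%

The read-out is a functional assay on the whole organism with Rattus norvegicus as the target, at a dose of 25 mg/kg; a lower number here means less inhibition, a higher number more inhibition at the dose given (going by the name of the read-out). In this assay compound 1 gives 0%, the lowest of the two numbers; compound 2 gives 34%, a number higher by an amount beyond the scatter. Going by the values given here, compound 2 differs from compound 1 in more than one place, so no single step can be drawn between them; the two values show only that a compound carrying chloro on an open core reaches a number well above compound 1.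

Compound 3, `CC1(C)C(=O)N(c2ccc(Cl)cc2)c2ncccc21`, has not yet been measured in this assay. It differs from compound 1 by chloro in place of methoxy on an aromatic carbon. Among the compounds with values here, no single-change step is measured, so the size of the step is uncertain; a modest rise is expected, though a step within the scatter cannot be ruled out. Compound 3 is expected to give 15%, with a range of 0% to 40%. The expected step from compound 1 to compound 3 is a number 15 percentage points higher from compound 1 to compound 3 (beyond the scatter).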

Compound 3, a percentage reported as inhibition, in the whole organism at one dose (the size of the read-out at that dose, not a potency): 65%
Compound 3: middle estimate off by 50 percentage points, on the low side; the measured number lies above the stated range.
By their numbers in this assay, from the lowest: compound 1; then compound 2; then compound 3.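

In this assay, going by these compounds alone, the position para to a large group on the six-membered aromatic ring of carbon only proves highly responsive to its substituent: chloro in place of methoxy gives a number 65 percentage points higher from compound 1 to compound 3 (beyond the scatter), a large step and the first single-change step. This one exchange, with the shared core unchanged, is enough to take compound 1 from 0% to a clearly measurable read-out at the dose given. Nothing shown accounts for the size of this step.

As far as these compounds go, it remains open whether the step comes from gaining chloro or from losing methoxy; fluoro, methyl or plain hydrogen on the same carbon would help separate the two. Also open, from the compounds shown here alone, is how an amine or a carboxylic acid at this position would behave on the same core.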